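The compounds below may be only part of what the source reports. "The series", "measured", "known", "first", "only" and "open" are said of these compounds alone.

Measured so far:
compound 1, `CC(C(=O)N1CCN(c2ccc(Cl)cc2)CC1)N1C(=O)CCC1=O`: 100%
compound 2, `CC(C(=O)N1CCN(c2ccc(C(F)(F)F)cc2)CC1)N1C(=O)CCC1=O`: 25%

In a functional assay on the whole organism (strain Swiss) with Mus musculus as the target, in the maximal electroshock model, with a stated time of 0.25 h, at a dose of 300 mg/kg by the intraperitoneal route (a higher number here means a stronger effect of the compound at the dose given, a lower number a weaker effect), compound 1 gives 100%, the highest of the two numbers shown; the nearest is compound 2 with 25%. Going by the values given here, the one step available is a number 75 percentage points lower from compound 1 to compound 2 (beyond the scatter). Compound 3, `CC(C(=O)N1CCN(c2cccc(F)c2)CC1)N1C(=O)CCC1=O`, is still to be measured in this assay. It differs from compound 1 by 3-fluorophenyl in place of 4-chlorophenyl on an amine nitrogen in a ring. The step from compound 1 to compound 2 bears on this change, since it too exchanges the chloro on the aromatic ring for another group, and it was large and downward; so a change at this ring can move the read-out a long way. Whether fluoro behaves like trifluoromethyl is not shown by any measured pair, so a smaller drop is expected, a number 45 percentage points lower from compound 1 to compound 3 (beyond the scatter), with wide uncertainty. For compound 3 the estimate is 55%, in the range 15% to 100%.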

Compound 3, a percentage reported as activity, at one dose (the size of the read-out at that dose, not a potency): 100%
Beside the measured number, compound 3's estimate is 45 percentage points below it; low and high end bracket the measured number.
By their numbers in this assay, from the lowest: compound 2; then compounds 1 and 3 (each within the scatter of the next).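

In this assay, the exchange of 4-chlorophenyl for 3-fluorophenyl on the amine nitrogen in the ring gives no change at the digits printed from compound 1 to compound 3 (within the scatter). Change at this aromatic ring therefore does not always cost read-out: the other exchange available, trifluoromethyl in place of chloro, gives a number 75 percentage points lower from compound 1 to compound 2 (beyond the scatter), so the outcome depends on the group that enters. No measurement on these compounds addresses why the two exchanges end so differently.

The step from 4-chlorophenyl to 3-fluorophenyl changes both the halogen and its place on the aromatic ring, so the compounds shown do not separate the two changes. Also open, from the compounds shown here alone, is how this assay would respond to a methoxy group or a nitrile on this aromatic ring, or to an unsubstituted phenyl.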